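A few compounds are considered here, and "the series" means these few. Any claim that something is new, unique, unknown or untested is made for them only; others in the source may bear on it.

Measured so far in an ADME assay on cells (Macrophage) for cytotoxicity, read by MTT assay, with a stated time of 24 h; a higher number here means that more compound is tolerated, a lower number that less compound is tolerated:

- compound 1 `O=C(/C=C/c1ccccc1Br)NNC(=O)c1ccc2c(c1)OCCO2`: 315000 nM
- compound 2 `O=C(/C=C/c1ccc(F)cc1)NNC(=O)c1ccc2c(c1)OCCO2`: 319000 nM
- compound 3 `Cc1cccc(/C=C/C(=O)NNC(=O)c2ccc3c(c2)OCCO3)c1`: 281000 nM

Compound 1 stands second highest of the three numbers. Its nearest neighbour is compound 2, with a 1.0-fold higher number from compound 1 to compound 2 (0.01 log units; within the scatter); its furthest is compound 3, with a 1.1-fold lower number from compound 1 to compound 3 (0.05 log units; within the scatter). The remaining pair shows a 1.1-fold lower number from compound 2 to compound 3 (0.06 log units; within the scatter). All three steps swap one aryl group on the double-bonded chain carbon for another, and none moves the number beyond the scatter; across the series the tolerated concentration is flat.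

Compound 4 `O=C(/C=C/c1ccccc1[N+](=O)[O-])NNC(=O)c1ccc2c(c1)OCCO2` is not yet measured. It differs from compound 1 by nitro in place of bromo on an aromatic carbon.

For the measured compounds named here, no measured step exchanges bromo for nitro, so the expectation rests only on the three aryl swaps above, each of which stayed within the scatter. Given that background, the step from compound 1 to compound 4 is expected to be a 1.1-fold lower number from compound 1 to compound 4 (0.02 log units; within the scatter), that is, no change beyond the scatter. Compound 4 is therefore estimated at 300000 nM in this assay, with a range from 150000 nM to 600000 nM.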

Compound 4, half-maximal cytotoxic concentration: 257000 nM
The estimate for compound 4 lay 1.2-fold (0.07 log units) above the measured number, within the range that was stated.
By their numbers in this assay, from the lowest: compounds 4, 3, 1 and 2 (each within the scatter of the next).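

In this assay, the exchange of nitro for bromo, on an aromatic carbon ortho to a large group, gives a 1.2-fold lower number from compound 1 to compound 4 (0.09 log units; within the scatter), so at this place 3 heavy atoms with 2 hydrogen-bond acceptors stand in for 1 heavy atom with none and the read-out stays within the scatter. Set against the other two aryl groups, the 2-nitrophenyl compound also stays within the scatter, with a 1.1-fold lower number from compound 3 to compound 4 (0.04 log units; within the scatter) and a 1.2-fold lower number from compound 2 to compound 4 (0.09 log units; within the scatter), so the flat picture now covers 2-bromophenyl, 4-fluorophenyl, 3-methylphenyl and 2-nitrophenyl, and none of the four compounds goes against it. Nothing on hand gives a reason for this flatness.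

On these data alone, whether the read-out stays equally flat with an amine or a carboxylic acid on this aromatic carbon remains open. As far as these compounds go, the shared core and the chain carrying the aryl group are the same in all four compounds, so what a longer chain or a change in the core would do to the tolerated concentration also remains open.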